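A Methoxy Group Added to a Thiourea Series

The source may hold more compounds than are shown below. What is called first, only, known or untested is meant among the compounds shown, and "the series" means these compounds.

Compound 1 `Cc1ccc(NC(=S)NC(=O)c2cn(-c3ccccc3)nc2-c2ccccc2)cc1` gives 2800 nM.
Compound 2 `O=C(NC(=S)Nc1ccc(F)cc1)c1cn(-c2ccccc2)nc1-c1ccccc1` gives 3500 nM.
Compound 3 `O=C(NC(=S)Nc1ccc(Cl)cc1)c1cn(-c2ccccc2)nc1-c1ccccc1` gives 3200 nM.

All three numbers come from a functional assay on A549 cells (Homo sapiens) for inhibition, read by CCK-8 assay, with a stated time of 48 h; a higher number here means a weaker inhibitor, a lower number a stronger inhibitor. Compound 1 stands at one end of the three numbers, yet the gaps to the others, a 1.3-fold higher number from compound 1 to compound 2 (0.10 log units; within the scatter) and a 1.1-fold higher number from compound 1 to compound 3 (0.06 log units; within the scatter), lie within the scatter, so no one of the three can be called stronger or weaker than another. Compound 2 and compound 3 likewise show only a 1.1-fold lower number from compound 2 to compound 3 (0.04 log units; within the scatter).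

Compound 4 `COc1ccc(-c2nn(-c3ccccc3)cc2C(=O)NC(=S)Nc2ccc(C)cc2)cc1` differs from compound 1 by methoxy in place of hydrogen on an aromatic carbon. Among the measured compounds shown here, none of the measured steps touches this change: each of them swaps methyl, fluoro and chloro among themselves at a different place, and each stayed within the scatter. There is thus no measured step that bears on adding a methoxy group, and nothing in the numbers shown points to a step beyond the scatter in this assay in either direction. Compound 4 is therefore expected to give about 2800 nM, with a range from 1200 nM to 6500 nM. The estimated step is no change at the digits printed from compound 1 to compound 4 (within the scatter).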

Compound 4, half-maximal inhibitory concentration: 1250 nM
Estimate against measurement, compound 4: 2.2-fold (0.35 log units) above, within the range that was stated.
By their numbers in this assay, from the lowest: compound 4; then compounds 1, 3 and 2 (each within the scatter of the next).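

In this assay the change from phenyl to 4-methoxyphenyl gives a 2.2-fold lower number from compound 1 to compound 4 (0.35 log units; beyond the scatter), a modest step, but the only one among these compounds that lies beyond the scatter. The swaps among methyl, fluoro and chloro, at a different place on the molecule, gave no such step, so this position is the one place shown where a change of group moves the number beyond the scatter. Nothing measured here accounts for the step.

The compounds shown hold only methoxy at this position, so they leave open whether ethoxy, a hydroxyl or an amine there would lower the number too, leave it unchanged, or raise it. They also leave open whether adding methoxy gives a similar step on compound 2 or compound 3, which carry fluoro and chloro in place of methyl.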